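Moving the ring nitrogen in a pyridyl chalcone

The compounds below may be only part of what the source reports. "The series", "measured", "known", "first", "only" and "open" are said of these compounds alone.

Of the compounds shown here, three have been tested in a functional assay on HepG2 cells (Homo sapiens) for antiproliferative activity, read by MTT assay, with a stated time of 48 h; a higher number here means a weaker inhibitor, a lower number a stronger inhibitor. Compound 1, with the structure `O=C(/C=C/c1cccnc1)c1nc2ccccc2[nH]1`, gives 8480 nM, the lowest of the two numbers recorded. Compound 2, with the structure `O=C(/C=C/c1ccccc1Br)c1nc2ccccc2[nH]1`, gives the higher number, 29200 nM, and the gap between compound 1 and compound 2 lies beyond the scatter of repeated measurements. Compound 3, with the structure `O=C(/C=C/c1ccccn1)c1nc2ccccc2o1`, is reported only as a limit of the assay, > 100000 nM; this is the limit of > 100000 nM in this assay, at which 1 of the 3 values shown sits.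

Compound 4, with the structure `O=C(/C=C/c1ccncc1)c1nc2ccccc2[nH]1`, has not yet been measured in this assay. It differs from compound 1 only in one respect: pyridin-4-yl in place of pyridin-3-yl on a double-bonded chain carbon bound to a double-bonded chain carbon. Going by the values given here, no measured pair in the set shows the effect of such a change, so no size can be read from the data. The change keeps the same count of atoms, donors and acceptors, and the author therefore expects a step from compound 1 to compound 4 that stays small, within or close to the scatter, with no clear direction, a 1.2-fold higher number from compound 1 to compound 4 (0.07 log units; within the scatter). On that basis compound 4 is estimated to give about 10000 nM in this assay, expected to fall between 3000 nM and 35000 nM.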

Compound 4, half-maximal inhibitory concentration: 6940 nM
Compound 4: the middle estimate sits 1.4-fold (0.16 log units) above what was measured, within the range that was stated.
By their numbers in this assay, from the lowest: compounds 4 and 1 (each within the scatter of the next); then compound 2. At a limit, above all of these: compound 3.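

Set against compound 1, the pyridin-4-yl of compound 4 gives the first matched comparison at this position, on a double-bonded chain carbon bound to a double-bonded chain carbon: in this assay there is a 1.2-fold lower number from compound 1 to compound 4 (0.09 log units; within the scatter). Going by these compounds alone, the two compounds have the same atoms joined differently, so the only change is the place of the ring nitrogen, and this read-out does not separate pyridin-3-yl from pyridin-4-yl on the shared core. None of the measurements shown gives a reason for this outcome or tells how either compound acts on the cells.

What the pair cannot say is whether this position would accept a change larger than a shift of the ring nitrogen, such as an amine or a methoxy group on the pyridine ring, or a carboxylic acid in its place. Compound 3 stands at a limit of the assay, > 100000 nM, and its core is not that of compound 4, so it does not settle how a further shift of the ring nitrogen would read on the core of compound 1.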